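From Ethoxy to Methoxy on a Shared Core

The compounds below may be only part of what the source reports. "The series", "measured", "known", "first", "only" and "open" are said of these compounds alone.

In a functional assay on PC-3 cells (Homo sapiens) for cytotoxicity (on this read-out higher numbers stand for weaker inhibition and lower numbers for stronger inhibition), compound 3 `CCOc1ccc2nc(NC(=O)CCCCCCC(=O)NO)sc2c1` gives 16.9 ug/mL and shares the upper end of the numbers with compound 1 `COc1ccc2nc(NC(=O)CCCCC(=O)NO)sc2c1` at 15.3 ug/mL, the two lying within the scatter of each other. Compound 2 `Cc1ccc2nc(NC(=O)CCCCCCC(=O)NO)sc2c1` stands well apart at 0.53 ug/mL. Compound 4 `COc1ccc2nc(NC(=O)CCCCCCC(=O)NO)sc2c1` departs from compound 3 in one place: hydrogen in place of methyl on a saturated chain carbon bound to an oxygen on an aromatic ring, with hydrogen in place of methyl on a saturated chain carbon bound to an oxygen on an aromatic ring, so ethoxy becomes methoxy. Among the measured compounds shown here, the only measured step bearing on this place is the large 32-fold higher number from compound 2 to compound 3 (1.50 log units; beyond the scatter). That step swaps ethoxy for methyl, whereas here an oxygen on the aromatic ring stays. Compound 4 is therefore expected to remain closer to compound 3, at 16.9 ug/mL, than to compound 2, at 0.53 ug/mL. In this assay the expected shift is toward lower numbers but not beyond the scatter. The estimated change is a 1.9-fold lower number from compound 3 to compound 4 (0.27 log units; within the scatter). For compound 4 the estimated value is 9 ug/mL, with an expected range from 2 ug/mL to 25 ug/mL.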

Compound 4, half-maximal inhibitory concentration: 1.56 ug/mL
For compound 4 the middle estimate is 5.8-fold (0.76 log units) above the measured one, outside the stated range (below it).
By their numbers in this assay, from the lowest: compound 2; then compound 4; then compounds 1 and 3 (each within the scatter of the next).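

In this assay the change from ethoxy to methoxy carries a large step of its own (an 11-fold lower number from compound 3 to compound 4 (1.03 log units; beyond the scatter)), although an oxygen stays on the aromatic ring. With methoxy in place of methyl the shift is only modest (a 2.9-fold higher number from compound 2 to compound 4 (0.47 log units; beyond the scatter)), so the oxygen alone does not bring the whole rise seen with ethoxy. The chain matters with methoxy too: 2-(hydroxycarbamoyl)ethyl in place of hydroxycarbamoyl on a saturated chain carbon gives a further step (a 9.8-fold lower number from compound 1 to compound 4 (0.99 log units; beyond the scatter)).

On these data alone, whether propoxy, a hydroxy group or an amine in place of the methoxy would stay near methoxy or move toward ethoxy remains open. Among the compounds shown here, nothing available explains why removing a single methyl from ethoxy shifts the number so far.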